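The compounds below may be only part of what the source reports. "The series", "measured", "known", "first", "only" and "open" are said of these compounds alone.

Measured in a functional assay with Oryctolagus cuniculus as the target; on this read-out higher numbers stand for weaker inhibition and lower numbers for stronger inhibition:
Compound 1 `COc1ccc(-c2nc(/N=C(\N)n3ccnc3)sc2-c2ccc(OC)cc2)cc1`: > 100 nM, a limit
Compound 2 `COc1ccc(-c2nc(CNC(C)=O)sc2-c2ccc(OC)cc2)cc1`: 15 nM
Compound 3 `COc1ccc(-c2nc(C(=O)N(C)C)sc2-c2ccc(OC)cc2)cc1`: < 100 nM, a limit

Compound 3 has no exact number in this assay, only the limit < 100 nM. Compound 4 `COc1ccc(-c2nc(C(=O)N3CCCCC3)sc2-c2ccc(OC)cc2)cc1` differs from compound 3 by piperidin-1-yl in place of dimethylamino on a carbonyl carbon, with piperidin-1-yl in place of dimethylamino on a carbonyl carbon.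

For the measured compounds named here, no measured step covers this change. Going by the values given here, the one readable step, an at least 6.6-fold lower number from compound 1 to compound 2 (0.82 log units; beyond the scatter), concerns a different exchange on an aromatic carbon. From the compounds shown here alone, the other two, a number no higher from compound 1 to compound 3 (the limit leaves the size open) and a step that the limit leaves unreadable from compound 2 to compound 3, stay open in size. The nearest exact number is that of compound 2, at 15 nM, which carries acetamidomethyl rather than a carbonyl-linked amine.

Going by these compounds, with so little to go on, no step beyond the scatter can be argued for in this assay, and the direction stays open. The expected step is a step that the limit leaves unreadable from compound 3 to compound 4. For compound 4 the estimated value is 35 nM, with an expected range from 8 nM to 150 nM.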

Compound 4, half-maximal inhibitory concentration: > 1000 nM
Compound 4 gave a limit, no number (the forecaster's own chance of this, stated with the estimate: 35%); middle value at least 28-fold (1.45 log units) away from the limit.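

In this assay, the group on the carbonyl carbon matters: piperidin-1-yl in place of dimethylamino gives an at least 10-fold higher number from compound 3 to compound 4 (1.00 log units; beyond the scatter) within a single exchange. For the compounds shown here, with (piperidin-1-yl)carbonyl in place of acetamidomethyl on an aromatic carbon, the result is an at least 66-fold higher number from compound 2 to compound 4 (1.82 log units; beyond the scatter) and compound 4 lies far on the weaker side of the only compound here with an exact number. The data shown hold no measurement that explains this loss of inhibition.

The step from compound 1 to compound 4 cannot be read, as both values are limits, and compound 3 still lacks an exact number. Open too, from the compounds shown here alone, is how other amines on the same carbonyl carbon, such as pyrrolidin-1-yl or morpholin-4-yl, would read out relative to dimethylamino and piperidin-1-yl.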